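Swapping a Urea for a Thiophene Amide on a Shared Core

This account rests on a few compounds, and the source may have more. Where it says the series, first, only, none or still open, it means among the compounds named here.

Three compounds share one core and differ mainly in the group joined to a carbonyl carbon that sits on that core. Compound 1 `CC(C)(C)C(=O)N1Cc2c(NC(=O)c3ccncc3)n[nH]c2C1(C)C` differs from the others in more than one place, and in a functional assay on A2780 cells (Homo sapiens) for antiproliferative activity, read by fluorescence, with a stated time of 72 h (on this read-out lower numbers stand for stronger inhibition and higher numbers for weaker inhibition), compound 1 gives 110 nM. Compound 2 `CN1CCC(C(=O)N2Cc3c(NC(=O)C4CCC4)n[nH]c3C2(C)C)CC1` carries a cyclobutyl group on that carbonyl carbon, and in this assay compound 2 gives 140 nM. Compound 3 `CN1CCC(C(=O)N2Cc3c(NC(=O)Nc4cccc(F)c4)n[nH]c3C2(C)C)CC1` carries a (3-fluorophenyl)amino group there, making the carbonyl part of a urea, and in this assay compound 3 gives 350 nM, the highest of the three numbers and so the weakest inhibitor here, with compound 2 nearest and compound 1 furthest.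

Among the compounds with values here, compound 4 `CN1CCC(C(=O)N2Cc3c(NC(=O)c4ccsc4)n[nH]c3C2(C)C)CC1` is the next step. thiophen-3-yl in place of (3-fluorophenyl)amino on a carbonyl carbon The one measured step that touches this carbonyl carbon, a 2.5-fold higher number from compound 2 to compound 3 (0.40 log units; beyond the scatter), shows that moving from a plain amide to the urea raised the number by a modest amount, beyond the scatter. Going back to an amide, now with thiophen-3-yl, should undo roughly that much, so compound 4 is expected to show a 2.2-fold lower number from compound 3 to compound 4 (0.34 log units; beyond the scatter). Compound 4 is therefore estimated at 160 nM, in a range from 60 nM to 450 nM.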

Compound 4, half-maximal inhibitory concentration: 140 nM
Compound 4: the middle estimate sits 1.1-fold (0.06 log units) above what was measured; the measured number falls inside the stated range.
By their numbers in this assay, from the lowest: compounds 1, 2 and 4 (each within the scatter of the next); then compound 3.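

In this assay, the urea is not needed at this carbonyl carbon: putting thiophen-3-yl in place of (3-fluorophenyl)amino gives a 2.5-fold lower number from compound 3 to compound 4 (0.40 log units; beyond the scatter). The new amide also matches the cyclobutyl amide, with no change at the digits printed from compound 2 to compound 4 (within the scatter), so among compounds 2, 3 and 4 the two amides read alike even though one carries a five-membered aromatic ring and the other cyclobutyl, while the urea, compound 3, stands apart. No supporting measurement is available to explain why the urea differs from the two amides.

The step from compound 3 to compound 4 removes the urea nitrogen and swaps the ring in a single change, so these compounds cannot show which of the two accounts for the difference; 3-fluorophenyl attached directly to the carbonyl carbon would separate them. Going by these compounds, it also remains open how far this tolerance extends, for example to an open chain such as n-butyl, or to a group carrying an amine or a carboxylic acid at this carbonyl carbon.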